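Swapping the Aromatic Group of Compound 2

The source may hold more compounds than are shown below. What is called first, only, known or untested is meant among the compounds shown, and "the series" means these compounds.

In a functional assay on HOS cells (Homo sapiens) for inhibition, with a stated time of 72 h (on this read-out lower numbers stand for stronger inhibition and higher numbers for weaker inhibition), compound 1 `NC1CCC(Nc2nc(NCc3ccc(-c4cccc(F)c4)cc3)c3ncn(C4CCCC4)c3n2)CC1` gives 211 nM and compound 2 `NC1CCC(Nc2nc(NCc3ccc(-n4cccn4)cc3)c3ncn(C4CCCC4)c3n2)CC1` gives 103 nM, the lower of the two numbers. Among the measured compounds shown here, the only measured step, a 2.0-fold lower number from compound 1 to compound 2 (0.31 log units; beyond the scatter), is modest but beyond the scatter, and it exchanges 3-fluorophenyl for 1H-pyrazol-1-yl on an aromatic carbon. Compound 3 `NC1CCC(Nc2nc(NCc3cc(Cl)ccc3O)c3ncn(C4CCCC4)c3n2)CC1` carries 5-chloro-2-hydroxyphenyl in place of 4-(1H-pyrazol-1-yl)phenyl on a saturated chain carbon bound to a nitrogen on an aromatic ring. This change is larger than the measured one, which therefore gives only a loose guide to its size. For the measured compounds named here, no measured compound shows the entering group, so the direction is uncertain. A modest move toward weaker inhibition is expected, as the estimated 3.4-fold higher number from compound 2 to compound 3 (0.53 log units; beyond the scatter). For compound 3 the estimate is 350 nM, with an expected range of 90 nM to 1400 nM.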

Compound 3, half-maximal inhibitory concentration: 490 nM
The estimate for compound 3 lay 1.4-fold (0.15 log units) below the measured number; the measured number falls inside the stated range.
By their numbers in this assay, from the lowest: compound 2; then compound 1; then compound 3.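

In this assay, among the compounds shown here, compound 3 is the first of the series with a single-ring group on a saturated chain carbon bound to a nitrogen on an aromatic ring, and replacing 4-(1H-pyrazol-1-yl)phenyl with 5-chloro-2-hydroxyphenyl gives a 4.8-fold higher number from compound 2 to compound 3 (0.68 log units; beyond the scatter). For the compounds shown here, compound 1 and compound 2 differ only in the outer ring of a two-ring group, so this step is the first to show what happens when that whole group is exchanged, and inhibition remains measurable after the exchange. Nothing available explains the shift.

From the compounds shown here alone, the chlorine, the hydroxyl and the loss of the second ring all change in one step, so their separate shares remain unknown. A plain phenyl, or a phenyl carrying only the chlorine or only the hydroxyl, would be needed to separate them.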